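A few compounds are considered here, and "the series" means these few. Any claim that something is new, unique, unknown or untested is made for them only; others in the source may bear on it.

Compound 1 `O=C(CCc1cccc2c1B(O)OC2)NCc1ccccc1` and compound 2 `O=C(CCc1cccc2c1B(O)OC2)Nc1cccc(-c2ccc(F)cc2)c1` share one core and differ only in the group carried on the amide nitrogen. In an ADME assay on WI-38 cells (Homo sapiens) for cytotoxicity, read by MTT assay, with a stated time of 72 h (a higher number here means a weaker inhibitor, a lower number a stronger inhibitor), compound 1 gives > 100000 nM, which is a limit of the assay and not a number. In this assay compound 2 gives 4100 nM. Compound 2 therefore stands on the only number shown in this assay; the result for compound 1 is the limit of > 100000 nM in this assay, at which 1 of the 2 values shown sits. Compound 3 `N#Cc1ccc(-c2cccc(NC(=O)CCc3cccc4c3B(O)OC4)c2)cc1` is not yet measured. It differs from compound 2 in one place: cyano in place of fluoro on an aromatic carbon. For the measured compounds named here, no measured pair shows what such an exchange does in this assay, so the expectation rests on compound 2 alone. Compound 3 is expected to give about 6000 nM in this assay, within a range from 2000 nM to 20000 nM. The expected step of a 1.5-fold higher number from compound 2 to compound 3 (0.17 log units; within the scatter) is small, not clearly beyond the usual scatter.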

Compound 3, half-maximal inhibitory concentration: 12000 nM
Compound 3: middle estimate off by 2.0-fold (0.30 log units), on the low side, and the stated range covers the measured number.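

In this assay, cyano in place of fluoro on an aromatic carbon, para to a large group, gives a 2.9-fold higher number from compound 2 to compound 3 (0.47 log units; beyond the scatter). For the compounds shown here, this is the first step that can be read between two numbers, and it shows that the group at this position is not indifferent: exchanging one substituent moves the number beyond the scatter, towards a weaker effect on the cells. Nothing shown here accounts for the size or direction of this step.

Left open is how an amine or a carboxylic acid at this same position would read in this assay, and whether such groups would continue the shift or reverse it. Also open, from the compounds shown here alone, is whether the exchange of fluoro for cyano would give a step of like size with a longer chain on the amide nitrogen.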